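Trimming a Pyridyl Ethoxy Chain Down to Ethyl

The source may hold more compounds than are shown below. What is called first, only, known or untested is meant among the compounds shown, and "the series" means these compounds.

Measured so far:
compound 1 `O=C(Nc1cccc(-c2ccco2)c1)C1CCCN(C(=O)c2cc(C(F)(F)F)cc(C(F)(F)F)c2)C1` gives 0%
compound 2 `O=C(Nc1cccc(OCCc2ccccn2)c1)C1CCCN(C(=O)c2cc(C(F)(F)F)cc(C(F)(F)F)c2)C1` gives 5%

Among the compounds with values here, in an ADME assay on PC-3 cells (Homo sapiens) for cytotoxicity, read by WST assay, tested at 100 uM (a lower number here means less inhibition, a higher number more inhibition at the concentration tested (going by the name of the read-out)), compound 2 stands together with compound 1 near the floor of the inhibition scale, and the only measured step, a number 5 percentage points higher from compound 1 to compound 2 (within the scatter), lies within the scatter. Compound 3 `CCc1cccc(NC(=O)C2CCCN(C(=O)c3cc(C(F)(F)F)cc(C(F)(F)F)c3)C2)c1` differs from compound 2 by ethyl in place of 2-(pyridin-2-yl)ethoxy on an aromatic carbon. That one measured step exchanged one aromatic side chain for another, a different kind of change from the one here, so it offers only a loose guide. Since both measured compounds show little inhibition, compound 3 is expected to behave alike, with a number 2 percentage points lower from compound 2 to compound 3 (within the scatter) meaning no step beyond the scatter. Compound 3 is estimated at 3%, within a range from 0% to 15%.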

Compound 3, a percentage reported as inhibition, at one concentration (the size of the read-out at that concentration, not a potency): 0%
Estimate against measurement, compound 3: 3 percentage points above; low and high end bracket the measured number.
By their numbers in this assay, from the lowest: compounds 1, 3 and 2 (each within the scatter of the next).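

In this assay this position, meta to a large group, accepts a much smaller group with no step beyond the scatter: ethyl in place of 2-(pyridin-2-yl)ethoxy gives a number 5 percentage points lower from compound 2 to compound 3 (within the scatter) and ethyl in place of furan-2-yl gives no change at the digits printed from compound 1 to compound 3 (within the scatter). A ring in this side chain is therefore not needed for the low numbers seen across these three compounds. No measurement at hand explains this lack of change. As far as these compounds go, whether an amine or a carboxylic acid at this position would raise the number remains open.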